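The source may hold more compounds than are shown below. What is called first, only, known or untested is meant among the compounds shown, and "the series" means these compounds.

Compound 2 has the structure `CCCCCCCCSc1nc(N)nc2c1ncn2/C=C1/CC1(CO)CO`. In an ADME assay on Akata cells (Homo sapiens) for cytotoxicity, with a stated time of 7 days (a lower number here means that less compound is tolerated, a higher number that more compound is tolerated), compound 2 gives > 20000 nM, which is a limit of the assay rather than a number. For the measured compounds named here, its one measured neighbour, compound 1 with the structure `CCCCNc1nc(N)nc2c1ncn2/C=C1/CC1(CO)CO`, differs from it by octylsulfanyl in place of butylamino on an aromatic carbon. In this assay compound 1 gives > 24000 nM, again a limit of the assay. The step that the two limits leave unreadable from compound 1 to compound 2 cannot be read in size, as both ends are limits: the limit of > 24000 nM in this assay, at which 1 of the 2 values shown sits, and (the limit of > 20000 nM in this assay, at which 1 of the 2 values shown sits). Compound 3, with the structure `Nc1nc(SCc2ccccc2)c2ncn(/C=C3/CC3(CO)CO)c2n1`, is the compound to be measured next. It differs from compound 2 in one place: phenyl in place of heptyl on a saturated chain carbon bound to a sulfur. Going by the values given here, no measured step involves this change, and the single step available is unreadable, so no size can be derived for the change in this assay; the expectation rests on compound 2 alone. Compound 3 is therefore expected to sit near the same ceiling, with the step that the limit leaves unreadable from compound 2 to compound 3 expected to stay within scatter. The estimate for compound 3 is 25000 nM, between 8000 nM and 80000 nM.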

Compound 3, half-maximal cytotoxic concentration: > 20000 nM
Compound 3 ended at the assay's limit; the forecaster's own chance of this, stated with the estimate: 70%; the middle value is on the limit's open side.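

In this assay, compound 3 also ends at a limit rather than a number, so its steps from compound 1 and from compound 2 cannot be read: the limit of > 20000 nM in this assay, at which 2 of the 3 values shown sit. The compounds shown leave open where the half-maximal cytotoxic concentration of each actually lies, and whether butylamino, octylsulfanyl and benzylsulfanyl differ at all in this read-out.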